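Pyridyl for chlorophenyl swap on two acrylic acid cores

The source may report more compounds than this note shows. Statements on the series, on what has been measured and on what is new or still open speak of the compounds shown alone.

Compound 1, `O=C(O)/C=C/c1ccc(/C(=C(\c2ccc(C(F)(F)F)cc2Cl)C2CCC2)c2ccc3scnc3c2)cc1`: in a functional assay on MCF7 cells (Homo sapiens) for antiproliferative activity, read by CellTiter-Glo, with a stated time of 5 days (on this read-out lower numbers stand for stronger inhibition and higher numbers for weaker inhibition), compound 1 gives 2.6 nM.
Compound 2, `O=C(O)/C=C/c1ccc(/C(=C(\c2ncc(C(F)(F)F)cc2Cl)C2CCC2)c2ccc3scnc3c2)cc1`: in this assay compound 2 gives 2.9 nM.
Compound 3, `O=C(O)/C=C/c1ccc(/C(=C(\c2ccc(C(F)(F)F)cc2Cl)C2CCC2)c2ccc(-c3cn[nH]c3)cc2)cc1`: in this assay compound 3 gives 16 nM.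

Compound 1 and compound 2 share one core and differ by one change, (3-chloro-5-(trifluoromethyl)pyridin-2-yl in place of 2-chloro-4-(trifluoromethyl)phenyl on a double-bonded chain carbon bound to a double-bonded chain carbon and a saturated ring carbon). The step this change made is a 1.1-fold higher number from compound 1 to compound 2 (0.05 log units; within the scatter); the two numbers cannot be told apart.

Compound 3 carries a different core. How the two cores differ is 4-(1H-pyrazol-4-yl)phenyl in place of 1,3-benzothiazol-5-yl on a double-bonded chain carbon bound to an aromatic carbon and a double-bonded chain carbon. On this core swap the number moves, a 6.2-fold higher number from compound 1 to compound 3 (0.79 log units; beyond the scatter), so compound 3 stands furthest from compound 1 and compound 2 in this assay among the three measured compounds.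

Compound 4, `O=C(O)/C=C/c1ccc(/C(=C(\c2ncc(C(F)(F)F)cc2Cl)C2CCC2)c2ccc(-c3cn[nH]c3)cc2)cc1`, is not yet measured. It differs from compound 3 by 3-chloro-5-(trifluoromethyl)pyridin-2-yl in place of 2-chloro-4-(trifluoromethyl)phenyl on a double-bonded chain carbon bound to a double-bonded chain carbon and a saturated ring carbon. Among the compounds with values here, the change is the same as the one between compound 1 and compound 2, made on the same kind of place, only now on the core of compound 3.

Within the data shown here, the expectation for compound 4 rests on the one precedent: the same change gave a 1.1-fold higher number from compound 1 to compound 2 (0.05 log units; within the scatter) on the other core. The expected step is therefore small, a 1.1-fold higher number from compound 3 to compound 4 (0.05 log units; within the scatter), within the usual scatter, resting on a 1.1-fold higher number from compound 1 to compound 2 (0.05 log units; within the scatter). Compound 4 is estimated at 18 nM in this assay. The expected range for compound 4 runs from 9 nM to 36 nM.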

Compound 4, half-maximal inhibitory concentration: 16 nM
Compound 4: the middle estimate sits 1.1-fold (0.05 log units) above what was measured, and the stated range covers the measured number.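

In this assay, 3-chloro-5-(trifluoromethyl)pyridin-2-yl in place of 2-chloro-4-(trifluoromethyl)phenyl gives no change at the digits printed from compound 3 to compound 4 (within the scatter), so on this pair the change carries from one core to the other without a gap beyond the scatter: the same change on two cores in this assay, a 1.1-fold higher number (0.05 log units; within the scatter) from compound 1 to compound 2 and no change at the digits printed (within the scatter) from compound 3 to compound 4, 1.1-fold (0.05 log units) apart, within the scatter of two such steps. The core change also reads alike with either of the two groups in place, at a 5.5-fold higher number from compound 2 to compound 4 (0.74 log units; beyond the scatter), which matches the step seen with the 2-chloro-4-(trifluoromethyl)phenyl group: the same change on two cores in this assay, a 6.2-fold higher number (0.79 log units; beyond the scatter) from compound 1 to compound 3 and a 5.5-fold higher number (0.74 log units; beyond the scatter) from compound 2 to compound 4, 1.1-fold (0.05 log units) apart, within the scatter of two such steps. Together the four compounds show that, in this one antiproliferative read-out, the group change and the core change behave as independent steps, but this rests on a single pair of groups on two cores and does not show that the same holds on any further core, in any other assay, or why the group change leaves the number in place.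

The compounds shown leave open whether the same independence would hold for a group other than the two compared here, such as a nitrile in place of the trifluoromethyl. They also leave open what an amide in place of the acrylic acid would do to either step on these two cores.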